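The source may hold more compounds than are shown below. What is called first, only, known or untested is meant among the compounds shown, and "the series" means these compounds.

Measured in a functional assay on A549 cells (Homo sapiens) for antiproliferative activity, read by MTT assay, with a stated time of 48 h; on this read-out lower numbers stand for stronger inhibition and higher numbers for weaker inhibition:
- Compound 1 `C/C(=C\CC/C(C)=C/CC[C@@H]1[C@@]2(C)CCC(=O)C(C)(C)[C@H]2CC[C@@]1(C)O)CC/C=C(\C)C(=O)OCc1cn(-c2ccccc2Br)nn1`: > 150000 nM, a limit and not a number
- Compound 2 `C/C(=C\CC/C(C)=C/CC[C@@H]1[C@@]2(C)CCC(=O)C(C)(C)[C@H]2CC[C@@]1(C)O)CC/C=C(\C)C(=O)OCc1cn(-c2cccc([N+](=O)[O-])c2)nn1`: > 150000 nM, a limit and not a number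

Compound 2 has no numerical position in this assay. Among the measured compounds shown here, the series so far is summed up by the limit of > 150000 nM in this assay, at which 2 of the 2 values shown sit.

Compound 3 `C/C(=C\CC/C(C)=C/CC[C@@H]1[C@@]2(C)CCC(=O)C(C)(C)[C@H]2CC[C@@]1(C)O)CC/C=C(\C)C(=O)OCc1cn(-c2ccc(Br)cc2)nn1` carries 4-bromophenyl in place of 3-nitrophenyl on an aromatic nitrogen, counted as 4-bromophenyl in place of 3-nitrophenyl on an aromatic nitrogen. For the measured compounds named here, the one measured step bearing on this change is a step that the two limits leave unreadable from compound 1 to compound 2. It swaps the same aryl position between a bromophenyl and 3-nitrophenyl, but it gives no size to carry over. Neither of the two aryl groups measured so far brought the read-out off the limit, so no step beyond the scatter is expected in this assay, and no direction can be assigned. The expected step is a step that the limit leaves unreadable from compound 2 to compound 3, and it should be read with that caution. The estimated value for compound 3 is 160000 nM, with an expected range of 70000 nM to 300000 nM, and a report at the limit is the likeliest outcome.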

Compound 3, half-maximal inhibitory concentration: > 150000 nM
Compound 3 was reported as a limit; the forecaster's own chance of this, stated with the estimate: 85%; the middle value is on the limit's open side.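

The steps among compound 1, compound 2 and compound 3 cannot be read in this assay, and the series remains summed up by a limit: the limit of > 150000 nM in this assay, at which 3 of the 3 values shown sit.

The compounds shown leave open whether any other group on this aromatic nitrogen, or any change to the shared core, would bring the read-out off the limit.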